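The source may hold more compounds than are shown below. What is called first, only, known or untested is meant among the compounds shown, and "the series" means these compounds.

Of the compounds shown here, two have been measured so far. Compound 1 `CCCCc1cc(C(C)=O)c(O)cc1OCCCCC#N` gives 13% in an assay on isolated protein for binding affinity to leukotriene B4 receptor 1 (Homo sapiens), tested at 1 uM; on this read-out lower numbers stand for less inhibition and higher numbers for more inhibition at the one concentration tested (going by the name of the read-out). Among the compounds with values here, compound 2 `CC(=O)c1cc(CC(C)O)c(OCCCCC#N)cc1O` gives 6% in this assay, and the one step seen, a number 7 percentage points lower from compound 1 to compound 2 (within the scatter), stays within the scatter, so the two numbers cannot be told apart. Compound 3 `CC(=O)c1cc(C(C)=O)c(OCCCCC#N)cc1O` differs from compound 2 by acetyl in place of 2-hydroxypropyl on an aromatic carbon. Within the data shown here, no measured step touches this kind of exchange, and the single step known was small, so no move beyond the scatter is expected: a number 2 percentage points higher from compound 2 to compound 3 (within the scatter). Compound 3 is therefore estimated at 8%, with a range from 0% to 22%.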

Compound 3, a percentage reported as inhibition, at one concentration (the size of the read-out at that concentration, not a potency): 0%
The estimate for compound 3 lay 8 percentage points above the measured number, within the range that was stated.
By their numbers in this assay, from the lowest: compounds 3, 2 and 1 (each within the scatter of the next, the first and the last beyond it).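

Acetyl in place of 2-hydroxypropyl on this aromatic carbon gives a number 6 percentage points lower from compound 2 to compound 3 (within the scatter) and so cannot be told apart from no change. Acetyl in place of butyl gives a number 13 percentage points lower from compound 1 to compound 3 (beyond the scatter) and is the first step here to pass the scatter, though only modestly, so the group at this place can shift the number a little. Nothing measured here accounts for either step.

From the compounds shown here alone, whether an amine, a carboxylic acid or a longer chain on this carbon would give more inhibition remains open.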